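Amine alkylation in the chalcone series: compound 1 to compound 4

A few compounds are considered here, and "the series" means these few. Any claim that something is new, unique, unknown or untested is made for them only; others in the source may bear on it.

Measured so far in a functional assay on PC-3 cells (Homo sapiens) for antiproliferative activity, with a stated time of 72 h; a higher number here means a weaker inhibitor, a lower number a stronger inhibitor:
compound 1 `CCN(C)Cc1c(OC)cc(OC)c(C(=O)/C=C/c2ccccc2Cl)c1O` gives 3 nM
compound 2 `COc1cc(O)c2c(=O)cc(-c3ccccc3Cl)oc2c1CN1CCCCC1` gives 63400 nM
compound 3 `COc1cc(OC)c2c(=O)cc(-c3ccccc3Cl)oc2c1CN1CCCCC1` gives 15500 nM

Compound 1 has the lowest of the three numbers, far below compound 3 and further still below compound 2; both of those gaps lie well beyond the scatter. Among the measured compounds shown here, the only step between measured compounds, a 4.1-fold lower number from compound 2 to compound 3 (0.61 log units; beyond the scatter), concerns methyl in place of hydrogen on an oxygen on an aromatic ring within the core shared by compound 2 and compound 3, not the core of compound 1, and not the amine.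

Compound 4 `CCN(CC)Cc1c(OC)cc(OC)c(C(=O)/C=C/c2ccccc2Cl)c1O` differs from compound 1 by methyl in place of hydrogen on a saturated chain carbon bound to an amine nitrogen. No measured pair changes the substituents on the amine nitrogen, so nothing shown bears directly on this step. For the measured compounds named here, with no such precedent, the change from ethyl(methyl)amino to diethylamino is expected to give no step beyond the scatter, a 1.3-fold higher number from compound 1 to compound 4 (0.12 log units; within the scatter). Compound 4 is therefore estimated at 4 nM in this assay, with a range from 1.5 nM to 12 nM.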

Compound 4, half-maximal inhibitory concentration: 4200 nM
The estimate for compound 4 lay 1100-fold (3.02 log units) below the measured number; measured number above the stated range.
By their numbers in this assay, from the lowest: compound 1; then compound 4; then compound 3; then compound 2.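

In this assay the substituents on the amine nitrogen prove to be a highly sensitive point in the core of compound 1, with the step of a 1400-fold higher number from compound 1 to compound 4 (3.15 log units; beyond the scatter). Compound 4 differs from compound 1 by one added methyl on a saturated chain carbon bound to an amine nitrogen, with ethyl(methyl)amino becoming diethylamino. So small a change in the (ethyl(methyl)amino)methyl group is therefore enough to separate a low-nanomolar compound from a micromolar one, and the earlier step on the aromatic oxygen gave no hint of this. Nothing measured here accounts for the size of this step.

The compounds shown leave open whether the number rises steadily with the size of the amine substituents or whether this one pair is a sharp exception. Dimethylamino or dipropylamino on the same core would separate these two readings.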